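A few compounds are considered here, and "the series" means these few. Any claim that something is new, unique, unknown or untested is made for them only; others in the source may bear on it.

Measured so far in a functional assay on brain (Rattus norvegicus, strain Wistar) for inhibition; on this read-out higher numbers stand for weaker inhibition and lower numbers for stronger inhibition: compound 1 `Cc1ccc(-c2c(C)[nH]c(=O)n2C)cc1` gives 85300 nM; compound 2 `CCCc1ccc(-c2c(C)[nH]c(=O)n2C)cc1` gives 21500 nM; compound 3 `CCCCCCCCCCCCc1ccc(-c2c(C)[nH]c(=O)n2C)cc1` gives 13000 nM.

The one counted change among these, (ethyl in place of hydrogen on a saturated chain carbon bound to an aromatic carbon), yields a 4.0-fold lower number from compound 1 to compound 2 (0.60 log units; beyond the scatter). The difference between the core of compound 1 and that of compound 3 is not broken down here; the two values simply show that compound 3 sits lower. Compound 3 and compound 2 lie within the scatter of each other.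

Compound 4 `CCCCCCCCCCCCCCc1ccc(-c2c(C)[nH]c(=O)n2C)cc1` carries the same kind of change, (ethyl in place of hydrogen on a saturated chain carbon, ten or more bonds along the chain from an aromatic carbon), though the ethyl enters at a different place on the chain than it does in the change from compound 1 to compound 2. Because compound 2 gives 21500 nM and compound 3 gives 13000 nM, two numbers within the scatter of each other, the step for compound 4 is expected to be small, a 1.3-fold lower number from compound 3 to compound 4 (0.11 log units; within the scatter). Compound 4 is thus estimated at 10000 nM, between 5000 nM and 22000 nM.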

Compound 4, half-maximal inhibitory concentration: 43800 nM
Beside the measured number, compound 4's estimate is 4.4-fold (0.64 log units) below it; measured number above the stated range.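

In this assay the ethyl in place of hydrogen gives a 3.4-fold higher number from compound 3 to compound 4 (0.53 log units; beyond the scatter). Carried from one core to another in this series, the change therefore keeps neither its size nor its direction: the same change on two cores in this assay, a 4.0-fold lower number (0.60 log units; beyond the scatter) from compound 1 to compound 2 and a 3.4-fold higher number (0.53 log units; beyond the scatter) from compound 3 to compound 4, 13-fold (1.13 log units) apart, beyond the scatter of two such steps. The two steps differ both in the core and in the place on the chain where the ethyl enters, and they do not show which of these matters, nor do they give a rule for any other core.

Going by these compounds, it remains open how an octyl chain or a hexadecyl chain would read in this assay. Also open, on these data alone, is what an amine or a carboxylic acid on the chain would do there.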